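From phenethylcarbonyl to (4-fluorophenyl)carbamoyl on the shared core

A few compounds are considered here, and "the series" means these few. Any claim that something is new, unique, unknown or untested is made for them only; others in the source may bear on it.

Compound 1 `COc1ccc(-c2cnc3nc(N)nc(N4CCN(c5ccc(C)cc5)CC4)c3n2)cc1OC` and compound 2 `COc1ccc(-c2cnc3nc(N)nc(N4CCN(C(=O)CCc5ccccc5)CC4)c3n2)cc1OC` share one core. In a functional assay on cells (T-cell, Homo sapiens) for inhibition (a lower number here means a stronger inhibitor, a higher number a weaker inhibitor), compound 1 gives 300 nM and compound 2 gives 100 nM; with the step of a 3.0-fold lower number from compound 1 to compound 2 (0.48 log units; beyond the scatter) compound 2 holds the lowest of the two numbers. Compound 3 `COc1ccc(-c2cnc3nc(N)nc(N4CCN(C(=O)Nc5ccc(F)cc5)CC4)c3n2)cc1OC` differs from compound 2 by (4-fluorophenyl)amino in place of phenethyl on a carbonyl carbon. Going by the values given here, the one measured step touched the amine nitrogen in a ring, not the carbonyl carbon, so it bears only loosely on this change; the carbonyl itself is kept. The expected step is no change at the digits printed from compound 2 to compound 3 (within the scatter), no clear direction beyond the scatter. Compound 3 is estimated at 100 nM, range 35 nM to 300 nM.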

Compound 3, half-maximal inhibitory concentration: 7 nM
Beside the measured number, compound 3's estimate is 14-fold (1.15 log units) above it; the whole stated range lies above it.
By their numbers in this assay, from the lowest: compound 3; then compound 2; then compound 1.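

In this assay, the group on the carbonyl carbon proves a strong lever: (4-fluorophenyl)amino in place of phenethyl gives a 14-fold lower number from compound 2 to compound 3 (1.15 log units; beyond the scatter), and the entering group carries 1 hydrogen-bond donor where the leaving group has none. On the amine nitrogen in a ring, (4-fluorophenyl)carbamoyl in place of 4-methylphenyl gives a 43-fold lower number from compound 1 to compound 3 (1.63 log units; beyond the scatter), well past the earlier step to compound 2. No available evidence accounts for this gain.

The compounds shown do not separate the amide hydrogen from the fluorine. Phenylamino on the carbonyl carbon, without fluorine, remains an open comparison, as does (4-fluorophenyl)methyl, which lacks that hydrogen.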